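A few compounds are considered here, and "the series" means these few. Any claim that something is new, unique, unknown or untested is made for them only; others in the source may bear on it.

In a functional assay on HL-60 cells (Homo sapiens) for cytotoxicity, read by MTT assay, with a stated time of 48 h (on this read-out lower numbers stand for stronger inhibition and higher numbers for weaker inhibition), compound 2 `CCN(CC)c1ccc(C(F)(F)F)cc1NC(=O)c1cccnc1` gives 71000 nM, the higher of the two numbers recorded there. Its nearest neighbour is compound 3 `O=C(Nc1cc(C(F)(F)F)ccc1Nc1ccc(Br)cc1)c1ccccc1`, which gives 11800 nM in this assay, a gap that lies beyond the scatter. Compound 1 `O=C(Nc1cc(C(F)(F)F)ccc1N1CCCCC1)c1ccccc1` is reported in this assay as "not active" (no number reported), with no number attached. Compound 4 `CCN(CC)c1ccc(C(F)(F)F)cc1NC(=O)c1ccncc1` is compound 2 with one rearrangement: pyridin-4-yl in place of pyridin-3-yl on a carbonyl carbon. Going by the values given here, no measured pair shows this exchange, so there is no step to lean on. The step is expected to be a 1.2-fold lower number from compound 2 to compound 4 (0.07 log units; within the scatter), nothing beyond the scatter in either direction. Compound 4 is therefore estimated at 60000 nM in this assay, within a range from 20000 nM to 200000 nM.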

Compound 4, half-maximal inhibitory concentration: 89700 nM
Estimate against measurement, compound 4: 1.5-fold (0.17 log units) below; the measured number falls inside the stated range.
By their numbers in this assay, from the lowest: compound 3; then compounds 2 and 4 (each within the scatter of the next).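

Going by these compounds alone, exchanging pyridin-3-yl for pyridin-4-yl on this carbonyl carbon supplies the first measured step at this position: in this assay, it is a 1.3-fold higher number from compound 2 to compound 4 (0.10 log units; within the scatter). Compounds 2 and 4 therefore cannot be told apart in this assay, so at this position and on this core, the two pyridinyl groups read alike. From the compounds shown here alone, what pyridin-2-yl or a carboxylic acid would give at this position remains open, as does whether the same exchange would read alike on the core of compound 3. No measured property bears on this result.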